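Fluoro to tert-butyl in an antiproliferative series

A few compounds are considered here, and "the series" means these few. Any claim that something is new, unique, unknown or untested is made for them only; others in the source may bear on it.

In a functional assay on SK-OV-3 cells (Homo sapiens) for antiproliferative activity, read by MTT assay, with a stated time of 72 h (on this read-out higher numbers stand for weaker inhibition and lower numbers for stronger inhibition), the measured compounds read as follows.
- Compound 1 `CCNC(=O)CCc1cccc2c1B(O)OC2` gives > 100000 nM as a limit
- Compound 2 `O=C(CCc1cccc2c1B(O)OC2)Nc1nccs1` gives > 100000 nM as a limit
- Compound 3 `O=C(CCc1cccc2c1B(O)OC2)Nc1ccc(F)cc1` gives 720 nM as a number

Compound 3 is the only one of the three with a true number. Compound 1 and compound 2 share the limit of > 100000 nM in this assay, at which 2 of the 3 values shown sit, for now. Compound 4 `CC(C)(C)c1ccc(NC(=O)CCc2cccc3c2B(O)OC3)cc1` differs from compound 3 in one group, with tert-butyl in place of fluoro on an aromatic carbon, para to a large group (tert-butyl in place of fluoro on an aromatic carbon). The nearest measured steps are an at least 130-fold lower number from compound 1 to compound 3 (2.14 log units; beyond the scatter) and an at least 130-fold lower number from compound 2 to compound 3 (2.14 log units; beyond the scatter), both bringing in 4-fluorophenyl on an amide-type nitrogen. Neither changes the fluoro itself, so they set no size here. With the aromatic ring kept, only a moderate move to a lower number is expected in this assay, and it may not clear the scatter. The step expected is a 2.4-fold lower number from compound 3 to compound 4 (0.38 log units; beyond the scatter). For compound 4 the estimated value is 300 nM, with an expected range from 50 nM to 2000 nM.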

Compound 4, half-maximal inhibitory concentration: 4200 nM
Beside the measured number, compound 4's estimate is 14-fold (1.15 log units) below it; the measured number lies above the stated range.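

Compound 3 and compound 4 share the core and the amide-linked aromatic ring, so this is the first listed step that changes the group on that ring rather than the group on the amide nitrogen. With tert-butyl in place of fluoro, this assay shows a 5.8-fold higher number from compound 3 to compound 4 (0.77 log units; beyond the scatter), so this position responds to the group it carries. Compound 4 still gives a true number rather than a limit.

The compounds shown leave open how a methoxy group, an amine or a carboxylic acid would read at this position. Nothing shown gives a cause for this step.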